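Cyclopentyl in Place of Isopropyl on the Shared Core

The compounds below may be only part of what the source reports. "The series", "measured", "known", "first", "only" and "open" are said of these compounds alone.

Compound 1 `COc1ccc(Nc2cc(-c3ccccc3)oc(=O)c2)cc1` gives 0.12 uM in a functional assay on DU-145 cells (Homo sapiens) for cytotoxicity, read by MTT assay, with a stated time of 72 h; a lower number here means that less compound is needed, a higher number that more compound is needed for the effect. Compound 2 `COc1ccc(Nc2cc(C(C)C)oc(=O)c2)cc1`, in this assay, reaches only the limit, > 30 uM. Because of the limit of > 30 uM in this assay, at which 1 of the 2 values shown sits, compound 2 stands without a measured number, and the step recorded as an at least 250-fold higher number from compound 1 to compound 2 (2.39 log units; beyond the scatter) is known only as a lower bound. Compound 3 `COc1ccc(Nc2cc(C3CCCC3)oc(=O)c2)cc1` differs from compound 2 by cyclopentyl in place of isopropyl on an aromatic carbon. For the measured compounds named here, only that one large step bears on the change, and it tells nothing about a cyclopentyl itself. Compound 3 is therefore expected near 8 uM, between 1.5 uM and 40 uM, an estimated at least 3.7-fold lower number from compound 2 to compound 3 (0.57 log units; beyond the scatter) in this assay.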

Compound 3, concentration for half-maximal effect: 5.42 uM
Compound 3: middle estimate off by 1.5-fold (0.17 log units), on the high side, within the range that was stated.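

In this assay, cyclopentyl in place of isopropyl on this aromatic carbon brings an at least 5.5-fold lower number from compound 2 to compound 3 (0.74 log units; beyond the scatter), giving the first measured number for a group without an aromatic ring here, though the step remains a lower bound: the limit of > 30 uM in this assay, at which 1 of the 3 values shown sits.

Cyclopentyl does not match phenyl at this position, however, with a 45-fold higher number from compound 1 to compound 3 (1.65 log units; beyond the scatter).

The compounds shown do not separate the ring itself from the larger carbon count as the source of the step from isopropyl. As far as these compounds go, how a cyclohexyl, an amine or a carboxylic acid at this position would read in this assay stays open.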